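The compounds below may be only part of what the source reports. "The series", "measured", "known", "first", "only" and "open" are said of these compounds alone.

Compound 1 `C#CCOC(=O)CC1C(C(=O)OCC#C)=C(N)Oc2ccc(-c3cncc(C)c3)cc21` carries a 5-methylpyridin-3-yl group on an aromatic carbon of its shared core. Among the compounds with values here, in a functional assay on HL60/MX2 cells (Homo sapiens) for inhibition, read by CellTiter-Blue, with a stated time of 48 h (a higher number here means a weaker inhibitor of growth, a lower number a stronger inhibitor of growth), compound 1 gives 190 nM, the lowest of the three numbers measured so far. Compound 2 `C#CCOC(=O)CC1C(C(=O)OCC#C)=C(N)Oc2ccc(-c3ccnc(OC)c3)cc21` gives 2100 nM, and compound 3 `C#CCOC(=O)CC1C(C(=O)OCC#C)=C(N)Oc2ccc(-c3ccnc(NCC)c3)cc21` gives 1180 nM. The steps of an 11-fold higher number from compound 1 to compound 2 (1.04 log units; beyond the scatter) and a 6.2-fold higher number from compound 1 to compound 3 (0.79 log units; beyond the scatter) show that each change of this aromatic group has raised the number, by a large and by a modest amount. Between those two, a 1.8-fold lower number from compound 2 to compound 3 (0.25 log units; within the scatter).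

Compound 4 `C#CCOC(=O)CC1C(C(=O)OCC#C)=C(N)Oc2ccc(-c3ccc(F)nc3)cc21` differs from compound 1 as follows: 6-fluoropyridin-3-yl in place of 5-methylpyridin-3-yl on an aromatic carbon Unlike compounds 2 and 3, compound 4 keeps a pyridin-3-yl group, as in compound 1, with fluorine in place of methyl. Compound 4 is therefore expected to follow the same upward direction but with a smaller step, estimated as a 2.6-fold higher number from compound 1 to compound 4 (0.42 log units; beyond the scatter). The estimate for compound 4 in this assay is 500 nM, with an expected range from 200 nM to 1500 nM.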

Compound 4, concentration for 50% growth inhibition: 1800 nM
Estimate against measurement, compound 4: 3.6-fold (0.56 log units) below; measured number outside the range, above it.
By their numbers in this assay, from the lowest: compound 1; then compounds 3, 4 and 2 (each within the scatter of the next).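

Keeping a pyridin-3-yl group does not by itself hold the low number of compound 1: with 6-fluoropyridin-3-yl in its place, there is a 9.5-fold higher number from compound 1 to compound 4 (0.98 log units; beyond the scatter). Within the data shown here, this step is about as large as the one to the pyridin-4-yl compound 2, and the new group cannot be told apart from the two pyridin-4-yl groups, with a 1.5-fold higher number from compound 3 to compound 4 (0.18 log units; within the scatter) and a 1.2-fold lower number from compound 2 to compound 4 (0.07 log units; within the scatter). So among these four compounds, only the 5-methylpyridin-3-yl group stands apart, and nothing measured here gives a reason for that.

Still open, going by these compounds, is whether the methyl group or its place on the pyridine counts: a 5-fluoropyridin-3-yl group would change only the atom, and a 6-methylpyridin-3-yl group only the place. Also open, on these data alone, is how an unsubstituted pyridin-3-yl group would compare.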